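Carbonyl substituent change at the side-chain amide

This account rests on a few compounds, and the source may have more. Where it says the series, first, only, none or still open, it means among the compounds named here.

Measured compounds:
compound 1 `Cc1nc2ccc(NCc3cccc(C(F)(F)F)c3)cc2n(CCNC(=O)[C@H](C)O)c1=O` — an assay for inhibition of acyl-CoA desaturase 1 (Rattus norvegicus), using microsomes (on this read-out lower numbers stand for stronger inhibition and higher numbers for weaker inhibition), 8000 nM
compound 2 `CC(=O)NCCn1c(=O)c(C)nc2ccc(NCc3cccc(C(F)(F)F)c3)cc21` — 162 nM

Going by the values given here, compound 2 gives the lower of the two numbers so far; compound 1 stands apart from it by the step of a 49-fold lower number from compound 1 to compound 2 (1.69 log units; beyond the scatter), which is beyond the scatter. Compound 3 `Cc1nc2ccc(NCc3cccc(C(F)(F)F)c3)cc2n(CCNC(N)=O)c1=O` is not yet measured. It differs from compound 2 by amino in place of methyl on a carbonyl carbon; cut one bond further out, this reads acetamido to ureido. Among the compounds with values here, the only measured step bears directly on it, since it also altered the substituent on the same carbonyl carbon: going from 1-hydroxyethyl to methyl gave a 49-fold lower number from compound 1 to compound 2 (1.69 log units; beyond the scatter), a large change. The entering amino group also carries one hydrogen-bond donor, so a move in the unfavourable direction is expected for compound 3, though a smaller one than that step. For compound 3 the expected step is a 3.1-fold higher number from compound 2 to compound 3 (0.49 log units; beyond the scatter). Compound 3 is therefore estimated at 500 nM, with a range of 150 nM to 2500 nM.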

Compound 3, half-maximal inhibitory concentration: 15 nM
Compound 3: the middle estimate sits 33-fold (1.52 log units) above what was measured, and the stated range ends above it.
By their numbers in this assay, from the lowest: compound 3; then compound 2; then compound 1.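

In this assay the carbonyl carbon of the side-chain amide remains highly sensitive even among small substituents: amino in place of methyl gives an 11-fold lower number from compound 2 to compound 3 (1.03 log units; beyond the scatter), so methyl is not the best group at this position among those shown. Across the three substituents on this carbonyl carbon the spread reaches a 530-fold lower number from compound 1 to compound 3 (2.73 log units; beyond the scatter), and the hydrogen-bond donor entering with amino goes with a lower number, not a higher one. Nothing available here accounts for this step.

Open, going by these compounds, is whether the low number needs the unsubstituted amino group, or persists with methylamino, dimethylamino or methoxy on the same carbonyl carbon. Also open, on these data alone, is whether the ureido group keeps this advantage on a longer chain, since all three compounds share one chain length.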